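Methylating the Ring Hydroxyl: Compound 3 to Compound 4

The source may hold more compounds than are shown below. What is called first, only, known or untested is meant among the compounds shown, and "the series" means these compounds.

Compound 1 `CCCOc1c(O)cc2oc(-c3ccccc3)cc(=O)c2c1O` gives 58900 nM in a functional assay on KB cells (Homo sapiens) for inhibition, with a stated time of 72 h; on this read-out lower numbers stand for stronger inhibition and higher numbers for weaker inhibition. Compound 2 `CCCOc1c(OC)cc2oc(-c3ccccc3)cc(=O)c2c1O` is reported only as a limit of the assay, > 100000 nM. Compound 3 `CCCCCCOc1cc2oc(-c3ccccc3)cc(=O)c2c(O)c1OCCCCCC` is likewise reported only as a limit, > 100000 nM.

Among the measured compounds shown here, the one measured step is an at least 1.6-fold higher number from compound 1 to compound 2 (0.22 log units; that floor lies within the scatter), made by methyl in place of hydrogen on an oxygen on an aromatic ring. Compound 4 `CCCCCCOc1cc2oc(-c3ccccc3)cc(=O)c2c(OC)c1OCCCCCC` carries the same change against compound 3, (methyl in place of hydrogen on an oxygen on an aromatic ring); the two places read the same word for word. How the core of compound 1 differs from that of compound 3 is not broken down here. Since compound 3 already sits at the limit and (the limit of > 100000 nM in this assay, at which 2 of the 3 values shown sit), the same change is expected to leave the number at or beyond that limit. The step is estimated as a step that the limit leaves unreadable from compound 3 to compound 4. Compound 4 is expected to give about 150000 nM, from 60000 nM to 400000 nM.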

Compound 4, half-maximal inhibitory concentration: 39100 nM
Compound 4: the middle estimate sits 3.8-fold (0.58 log units) above what was measured; the measured number lies below the stated range.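

In this assay, replacing hydroxy with methoxy gives an at least 2.5-fold lower number from compound 3 to compound 4 (0.40 log units; beyond the scatter). Set beside the earlier step, the same change does not carry over unchanged from one core to the other: the same change on two cores in this assay, an at least 1.6-fold higher number (0.22 log units; that floor lies within the scatter) from compound 1 to compound 2 and an at least 2.5-fold lower number (0.40 log units; beyond the scatter) from compound 3 to compound 4, at least 4.3-fold (0.63 log units) apart, beyond the scatter of two such steps Both steps are only floors, resting on compound 2 and compound 3, which are reported as limits of the assay, and the data do not show what causes the difference between the two cores.

Left open is how the same change reads on a core carrying a butyl or an octyl chain. Also open, from the compounds shown here alone, is whether an ethyl group on that oxygen would give a step like that of methyl.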